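The source may report more compounds than this note shows. Statements on the series, on what has been measured and on what is new or still open speak of the compounds shown alone.

Of the compounds shown here, three sharing one core have been tested in an ADME assay on HeLa cells (Homo sapiens) for cytotoxicity, read by microscopy; on this read-out higher numbers stand for lower toxicity in this test and lower numbers for higher toxicity in this test. Compound 1 `CSc1nc(OCCCNc2ccnc3cc(Cl)ccc23)c(C#N)c(-c2ccccc2)n1` gives 4000 nM, compound 2 `CSc1nc(NCCCCNc2ccnc3cc(Cl)ccc23)c(C#N)c(-c2cccc([N+](=O)[O-])c2)n1` gives 100000 nM, and compound 3 `COc1ccc(-c2nc(SC)nc(NCCCCNc3ccnc4cc(Cl)ccc34)c2C#N)cc1` gives 20000 nM. Compound 3 thus holds the second highest of the three numbers, sitting between compound 1 and compound 2. Compound 4 `COc1cc(-c2nc(SC)nc(NCCCCNc3ccnc4cc(Cl)ccc34)c2C#N)cc(OC)c1OC` differs from compound 3 in one place: 3,4,5-trimethoxyphenyl in place of 4-methoxyphenyl on an aromatic carbon. Among the measured compounds shown here, the only measured step that bears on this change of the same ring gave a 5.0-fold lower number from compound 2 to compound 3 (0.70 log units; beyond the scatter); nothing shows what the extra methoxy groups do. Compound 4 is therefore expected to show no change at the digits printed from compound 3 to compound 4 (within the scatter), staying close to compound 3. The value of compound 4 is estimated at 20000 nM, with a range from 7000 nM to 60000 nM.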

Compound 4, minimum cytotoxic concentration: 20000 nM
Beside the measured number, compound 4's estimate shows no gap at the digits printed; the range from low to high includes it.
By their numbers in this assay, from the lowest: compound 1; then compounds 3 and 4 (each within the scatter of the next); then compound 2.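

Putting 3,4,5-trimethoxyphenyl in place of 4-methoxyphenyl at this position, ortho to a cyano group, brings no change at the digits printed from compound 3 to compound 4 (within the scatter) in this assay, so this read-out does not separate these two groups. Measured against 3-nitrophenyl, the new group gives a 5.0-fold lower number from compound 2 to compound 4 (0.70 log units; beyond the scatter) and so matches the step already seen for 4-methoxyphenyl. Nothing available explains why the added methoxy groups leave the number unchanged. Still open, from the compounds shown here alone, is what an amine or a carboxylic acid on this phenyl ring would do to the number.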